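The source may hold more compounds than are shown below. What is called first, only, known or untested is meant among the compounds shown, and "the series" means these compounds.

Measured compounds: compound 1 `O[C@H](COc1ccc(C(F)(F)F)cc1)CN1CCN(c2ccc(F)cc2)CC1`, compound 2 `O[C@H](COc1ccc(Cl)cc1)CN1CCN(c2ccc(F)cc2)CC1` and compound 3 `O[C@@H](COc1ccc(Cl)cc1)CN1CCN(c2ccccc2F)CC1`. In an assay on HEK293 cells for inhibition of Voltage-dependent T-type calcium channel subunit alpha-1G (Homo sapiens), read by patch clamp, tested at 10 uM (on this read-out lower numbers stand for less inhibition and higher numbers for more inhibition at the one concentration tested (going by the name of the read-out)), compound 1 gives 59.2%, compound 2 gives 28.3%, and compound 3 gives 46.9%.

Compound 1 and compound 2 share one core; compound 3 carries a different core, and the difference between the two cores is not broken down here. Within the first core the change trifluoromethyl in place of chloro on an aromatic carbon made the step of a number 30.9 percentage points higher from compound 2 to compound 1 (beyond the scatter). Compound 4 `O[C@@H](COc1ccc(C(F)(F)F)cc1)CN1CCN(c2ccccc2F)CC1`, not yet measured in this assay, is compound 3 with the same change, (trifluoromethyl in place of chloro on an aromatic carbon), at the same place. Because compound 3 already stands at 46.9%, a rise of the earlier size would come close to the top of the scale, so a somewhat smaller step is expected: a number 23.1 percentage points higher from compound 3 to compound 4 (beyond the scatter). Compound 4 is therefore estimated at 70%, between 50% and 88%.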

Compound 4, a percentage reported as inhibition, at one concentration (the size of the read-out at that concentration, not a potency): 50.2%
The estimate for compound 4 lay 19.8 percentage points above the measured number; low and high end bracket the measured number.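

On the core of compound 3, trifluoromethyl in place of chloro gave a number 3.3 percentage points higher from compound 3 to compound 4 (within the scatter) in this assay. For the compounds shown here, the same change therefore did not carry over at the same size from one core to the other: the same change on two cores in this assay, a number 30.9 percentage points higher (beyond the scatter) from compound 2 to compound 1 and a number 3.3 percentage points higher (within the scatter) from compound 3 to compound 4, 27.6 percentage points apart, beyond the scatter of two such steps With only two pairs, this shows that the size of the step depends on the core, but it does not show which difference between the cores accounts for the gap or how the change would behave on a further core.

All the compounds shown carry either chloro or trifluoromethyl at this place, so how a nitrile or a methoxy group there would read in this assay remains open.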